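This account rests on a few compounds, and the source may have more. Where it says the series, first, only, none or still open, it means among the compounds named here.

Among the compounds with values here, in an in vitro assay on cells for inhibition of Amine oxidase [flavin-containing] B (Homo sapiens), read by fluorescence and Amplex Red, with stated times of 30 min and 45 min (a lower number here means a stronger inhibitor, a higher number a weaker inhibitor), compound 1 `O=C(CCc1ccccc1)Nc1nc2ccccc2c(=O)s1` gives 17.6 nM, the lowest of the three numbers measured so far. Its nearest neighbour is compound 3 `COc1cccc(CCCC(=O)Nc2nc3ccccc3c(=O)s2)c1`, which gives 389 nM, and furthest from it stands compound 2 `O=C(CCCc1ccc(Cl)c(Cl)c1)Nc1nc2ccccc2c(=O)s1`, which gives 3440 nM. Both of those gaps lie beyond the scatter of this assay. Within the data shown here, the only single-place step among the measured compounds is an 8.8-fold lower number from compound 2 to compound 3 (0.95 log units; beyond the scatter); it swaps one whole aryl group for another on a longer chain and is the one comparison available.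

Compound 4 `O=C(CCc1ccccc1F)Nc1nc2ccccc2c(=O)s1` differs from compound 1 by fluoro in place of hydrogen on an aromatic carbon, a change that reads, one bond further out, as phenyl to 2-fluorophenyl. Among the measured compounds shown here, no measured pair shows this change, and no measured compound carries fluorine at all. The change from compound 2 to compound 3 concerns a different chain length and a different set of substituents, so it bears on the present question only loosely. The expectation therefore rests on the smallness of the alteration: a step of a 1.1-fold higher number from compound 1 to compound 4 (0.06 log units; within the scatter) is expected, which would lie within the scatter. Compound 4 is estimated at 20 nM, with a range from 7 nM to 60 nM.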

Compound 4, half-maximal inhibitory concentration: 11.2 nM
Estimate against measurement, compound 4: 1.8-fold (0.25 log units) above; measured number inside the range.
By their numbers in this assay, from the lowest: compounds 4 and 1 (each within the scatter of the next); then compound 3; then compound 2.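

In this assay, fluoro in place of hydrogen on an aromatic carbon, ortho to a large group, can now be read directly, and the result is a 1.6-fold lower number from compound 1 to compound 4 (0.20 log units; within the scatter). Within the data shown here, compound 1 and compound 4 therefore cannot be told apart in this assay, which shows that this place on the phenyl ring can carry a single fluorine atom while the number stays in the same low range, something no earlier compound could show because none contained fluorine. No accompanying measurement bears on this result, so the shown data offer no explanation for it.

From the compounds shown here alone, whether a trifluoromethyl group, a nitrile or a hydroxyl group at this same place would also leave the number undisturbed remains open, as does the outcome of placing fluoro elsewhere on the ring. Also open, going by these compounds, is whether the single fluorine atom would have the same outcome on a longer chain, and whether chloro or methoxy would be accommodated on the chain of compound 1.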